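This account rests on a few compounds, and the source may have more. Where it says the series, first, only, none or still open, it means among the compounds named here.

Compound 1 `O[C@@H]1[C@@H](OCc2ccccc2)[C@H](OCc2ccccc2)[C@@H](COCc2ccccc2)O[C@H]1CC1CCCCC1`: 4100 nM
Compound 2 `C#CC[C@@H]1O[C@H](COCc2ccccc2)[C@@H](OCc2ccccc2)[C@H](OCc2ccccc2)[C@H]1O`: "not active" (no number reported)
Compound 3 `C=CC[C@@H]1O[C@H](COCc2ccccc2)[C@@H](OCc2ccccc2)[C@H](OCc2ccccc2)[C@H]1O`: 15100 nM

All three compounds were tested in a functional assay on HL-60 cells (Homo sapiens) for antiproliferative activity, read by MTT assay; on this read-out higher numbers stand for weaker inhibition and lower numbers for stronger inhibition. Of the two compounds that gave a number, compound 3 has the higher one, so it is the weaker inhibitor of that pair. Compound 2 gave no number to compare.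

Compound 4 `O[C@@H]1[C@@H](OCc2ccccc2)[C@H](OCc2ccccc2)[C@@H](COCc2ccccc2)O[C@H]1CC1CC1`, still unmeasured, differs from compound 3 in one group: cyclopropyl in place of vinyl on a saturated chain carbon bound to a saturated ring carbon. This is cyclopropyl in place of vinyl on a saturated chain carbon bound to a saturated ring carbon. The same difference can also be read as allyl to cyclopropylmethyl.

Among the compounds with values here, only one measured step bears on this change: a 3.7-fold higher number from compound 1 to compound 3 (0.57 log units; beyond the scatter). It is modest but beyond the scatter, and it replaces cyclohexyl with vinyl at the same place. Compound 4 gives up the vinyl and regains a ring, though a different one from the cyclohexyl of compound 1. A partial return towards compound 1 therefore seems likely, but a single step is thin evidence. In this assay, a small step towards a lower number is expected, and it may not clear the scatter. That expectation amounts to an estimated 1.9-fold lower number from compound 3 to compound 4 (0.28 log units; within the scatter). For compound 4, the expected value is 8000 nM, within an estimated range of 3500 nM to 18000 nM.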

Compound 4, half-maximal inhibitory concentration: "not active" (no number reported)
For compound 4 the study gives words and no number; the estimate stays without a comparison.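

Within the data shown here, compound 4, like compound 2, is reported in words only, so no step from compound 3 to compound 4 can be read, and no evidence here bears on that result. The compounds shown leave open how far this assay separates cyclopropyl from vinyl at this place.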